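Nitro in place of methyl on the benzyl ether

The compounds below may be only part of what the source reports. "The series", "measured", "known", "first", "only" and "open" are said of these compounds alone.

Measured compounds:
compound 1 `COc1cccc(OC)c1OCCNCCOc1ccccc1OCc1ccccc1` gives 0.0676 nM in an assay on CHO cells for displacement of a labelled ligand from Alpha-1D adrenergic receptor (Homo sapiens); a higher number here means a weaker inhibitor, a lower number a stronger inhibitor
compound 2 `COc1cccc(OC)c1OCCNCCOc1ccccc1OCc1ccc(C)cc1` gives 0.0631 nM in this assay

Compound 2 gives the lowest of the two numbers shown, but its single neighbour, compound 1, sits within the scatter of it: a 1.1-fold lower number from compound 1 to compound 2 (0.03 log units; within the scatter). On these numbers the two compounds are not distinguishable.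

Compound 3 `COc1cccc(OC)c1OCCNCCOc1ccccc1OCc1cccc([N+](=O)[O-])c1` has not yet been measured. It differs from compound 2 in one place: 3-nitrophenyl in place of 4-methylphenyl on a saturated chain carbon bound to an oxygen on an aromatic ring.

Within the data shown here, only one measured step exists, and it bears on this change only loosely. It shows that exchanging hydrogen for methyl on the same aromatic ring leaves the number unchanged within the scatter. Among the measured compounds shown here, the step to compound 3 is larger, swapping a methyl for a nitro group and moving it to another position on the ring, so no measured step covers it directly. The expectation is therefore a modest step, most likely toward a higher number, with wide uncertainty: a 1.6-fold higher number from compound 2 to compound 3 (0.20 log units; within the scatter) is expected. Compound 3 is estimated at 0.1 nM, within a range from 0.03 nM to 0.4 nM.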

Compound 3, inhibition constant: 0.0631 nM
Estimate against measurement, compound 3: 1.6-fold (0.20 log units) above, and the stated range covers the measured number.
By their numbers in this assay, from the lowest: compounds 2, 3 and 1 (each within the scatter of the next).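

Placing 3-nitrophenyl in place of 4-methylphenyl on a saturated chain carbon bound to an oxygen on an aromatic ring gives, in this assay, no change at the digits printed from compound 2 to compound 3 (within the scatter), and comparing the nitro group with hydrogen on this ring gives a 1.1-fold lower number from compound 1 to compound 3 (0.03 log units; within the scatter), so the three compounds cannot be told apart. Until now, only methyl had been compared with hydrogen on this ring; compound 3 extends the comparison to a substituent with nitrogen and oxygen atoms, and to a ring that enters with 2 hydrogen-bond acceptors where 4-methylphenyl has 0. Across these three compounds, and with none going against it, the number in this assay does not separate hydrogen, methyl and nitro on this ring, and nothing given here accounts for that.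

The compounds shown leave open whether the same holds for an amine or a carboxylic acid on this ring, or for a longer chain between the ring and the ether oxygen. Among these compounds, they also leave open whether any group at this place can move the number in this assay beyond the scatter, since every step so far lies within it.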